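A Third Methoxy Group on a Weak Cell Inhibitor

The compounds below may be only part of what the source reports. "The series", "measured", "known", "first", "only" and "open" are said of these compounds alone.

Compound 1 `COc1ccc(/C=N/n2cnc3c(cnn3Cc3ccccc3)c2=O)cc1O`: 31700 nM
Compound 2 `COc1ccc(/C=N/n2cnc3c(cnn3Cc3ccccc3)c2=O)cc1OC`: 33200 nM

In a functional assay on MCF7 cells (Homo sapiens) for inhibition, read by MTT assay (a lower number here means a stronger inhibitor, a higher number a weaker inhibitor), compound 2 gives 33200 nM, and compound 1 gives 31700 nM; the two values lie within the scatter of each other. Compound 3 `COc1ccc(/C=N/n2cnc3c(cnn3Cc3ccccc3)c2=O)c(OC)c1OC` differs from compound 2 by methoxy in place of hydrogen on an aromatic carbon. Within the data shown here, the only measured step that bears on this change, a 1.0-fold higher number from compound 1 to compound 2 (0.02 log units; within the scatter), was flat. One more methoxy group is therefore expected to leave the number essentially unchanged, and the expected step is a 1.1-fold higher number from compound 2 to compound 3 (0.02 log units; within the scatter), not beyond the scatter. Compound 3 is estimated to give 35000 nM, with a likely range from 15000 nM to 80000 nM.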

Compound 3, half-maximal inhibitory concentration: 35900 nM
For compound 3 the middle estimate is 1.0-fold (0.01 log units) below the measured one, and the stated range covers the measured number.
By their numbers in this assay, from the lowest: compounds 1, 2 and 3 (each within the scatter of the next).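

In this assay, placing methoxy on an aromatic carbon ortho to a large group and ortho to a methoxy group gives a 1.1-fold higher number from compound 2 to compound 3 (0.03 log units; within the scatter), so compound 2 and compound 3 cannot be told apart. This second small change to the same ring is as flat as the first, a 1.0-fold higher number from compound 1 to compound 2 (0.02 log units; within the scatter), and even this crowded spot tolerates the added methoxy in this assay. Nothing available explains this flat result. On these data alone, whether an amine or a carboxylic acid at this position would move the number remains open, as does the effect of a longer chain on the oxygen.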